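Shifting the Fluorine on the Phenyl Ring

A few compounds are considered here, and "the series" means these few. Any claim that something is new, unique, unknown or untested is made for them only; others in the source may bear on it.

compound 1, `CCCNC(=O)/N=C(\N)NCCCc1sc(N)nc1C`: 105 nM
compound 2, `Cc1nc(N)sc1CCCN/C(N)=N/C(=O)NC(c1ccccc1)C(C)C`: 35.5 nM
compound 3, `Cc1nc(N)sc1CCCN/C(N)=N/C(=O)NC(C)c1ccccc1F`: 28.8 nM

Of the compounds shown here, three sharing one core have been measured in an assay on membranes from Sf9 cells for displacement of a labelled ligand from histamine H2 receptor (Homo sapiens), read by scintillation counting, with a stated time of 60 min; a higher number here means a weaker inhibitor, a lower number a stronger inhibitor. Compound 3 shows the lowest of the three numbers. Compound 2 sits within the scatter of compound 3, so the two cannot be ordered. Compound 1 lies beyond the scatter, with the higher number of the two.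

Compound 4 `Cc1nc(N)sc1CCCN/C(N)=N/C(=O)NC(C)c1ccc(F)cc1` has not yet been measured. It differs from compound 3 in a single place: 4-fluorophenyl in place of 2-fluorophenyl on a saturated chain carbon bound to an amide-type nitrogen and a saturated chain carbon. Among the measured compounds shown here, no pair of measured compounds shows what moving a substituent around that ring does, so there is no measured step to lean on. Compound 2 and compound 3 carry different groups at the same place and still fall within the scatter of each other, which offers some hint that this region accepts change without a large shift. The expected step is a 1.2-fold higher number from compound 3 to compound 4 (0.08 log units; within the scatter), nothing beyond the scatter in either direction. Compound 4 is estimated to give about 35 nM in this assay, with a range from 12 nM to 100 nM.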

Compound 4, inhibition constant: 31.6 nM
For compound 4 the middle estimate is 1.1-fold (0.04 log units) above the measured one; the range from low to high includes it.
By their numbers in this assay, from the lowest: compounds 3, 4 and 2 (each within the scatter of the next); then compound 1.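

In this assay, among the compounds shown here, the exchange of 2-fluorophenyl for 4-fluorophenyl gives a 1.1-fold higher number from compound 3 to compound 4 (0.04 log units; within the scatter) and forms the first pair here that differs in one place, showing directly what moving the fluorine around this ring does. On a saturated chain carbon bound to an amide-type nitrogen and a saturated chain carbon, these two fluorophenyl groups therefore cannot be told apart in this read-out. Nothing measured here explains this outcome.

The compounds shown leave open whether phenyl without fluorine, 4-chlorophenyl or 4-methoxyphenyl on the same carbon would also stay within the scatter of compound 3 . For the compounds shown here, no pair isolates the methyl group on that carbon either, so it remains open what an ethyl group in its place would do.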